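Isobutyl to methoxyethyl on the piperidine-phenyl core

The source may report more compounds than this note shows. Statements on the series, on what has been measured and on what is new or still open speak of the compounds shown alone.

Compound 3 `Cc1c(CC(C)C)c(=O)on1C(=O)N1CCC(c2ccccc2)CC1` gives 10 nM in an assay (strain Wistar) for inhibition of Hormone-sensitive lipase (Rattus norvegicus), read by spectrophotometry; a lower number here means a stronger inhibitor, a higher number a weaker inhibitor. Compound 1 `Cc1c(CC(C)C)c(=O)on1C(=O)N1CCCCC1` gives 5 nM, and compound 2 `Cc1c(C2CCCC2)c(=O)on1C(=O)N1CCCCC1` gives 6 nM. The step of a 2.0-fold higher number from compound 1 to compound 3 (0.30 log units; within the scatter) and the step of a 1.2-fold higher number from compound 1 to compound 2 (0.08 log units; within the scatter) both stay within the scatter, so compound 3 is not separated from compound 1 or compound 2 beyond the scatter; the three numbers sit together.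

Compound 4 `COCCc1c(C)n(C(=O)N2CCC(c3ccccc3)CC2)oc1=O` differs from compound 3 by methoxymethyl in place of isopropyl on a saturated chain carbon bound to an aromatic carbon; cut one bond further out, the same difference reads isobutyl to 2-methoxyethyl. Within the data shown here, no measured step changes this part of the molecule in this way. Among the measured compounds shown here, the only step that touches the isobutyl group at all is a 1.2-fold higher number from compound 1 to compound 2 (0.08 log units; within the scatter), which replaced the whole group with a ring and gave a number within the scatter; the step of a 2.0-fold higher number from compound 1 to compound 3 (0.30 log units; within the scatter) concerns a different part and also stayed within the scatter. On these grounds the expected step of a 1.5-fold higher number from compound 3 to compound 4 (0.18 log units; within the scatter) is small, with no direction beyond the scatter established. Compound 4 is expected to give about 15 nM in this assay, within the range 5 nM to 45 nM.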

Compound 4, half-maximal inhibitory concentration: 11 nM
Compound 4: middle estimate off by 1.4-fold (0.13 log units), on the high side, within the range that was stated.
By their numbers in this assay, from the lowest: compounds 1, 2, 3 and 4 (each within the scatter of the next, the first and the last beyond it).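

Replacing isobutyl with 2-methoxyethyl gives a 1.1-fold higher number from compound 3 to compound 4 (0.04 log units; within the scatter) in this assay, so on this core the position takes an oxygen-bearing chain, with one hydrogen-bond acceptor counted in methoxymethyl and none in isopropyl, without a shift beyond the scatter. Among these compounds, the only earlier change here was an all-carbon one, cyclopentyl in place of isobutyl, at a 1.2-fold higher number from compound 1 to compound 2 (0.08 log units; within the scatter), and the range of groups seen to stay within the scatter at this position now includes a chain holding a heteroatom. No evidence to hand bears on this result.

On these data alone, whether an amine or a carboxylic acid in place of methoxymethyl, or a longer chain, would also stay within the scatter remains open. Also open, as far as these compounds go, is whether 2-methoxyethyl behaves the same way on the core of compound 1, which lacks the phenyl.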